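Compound 3 to compound 4: pyridin-3-yl in place of pyridin-2-yl

The compounds below may be only part of what the source reports. "The series", "measured", "known", "first", "only" and "open" are said of these compounds alone.

Of the compounds shown here, three have been measured so far in a physicochemical assay for solubility, read by nephelometry, measured as kinetic solubility, at pH 6.5; on this read-out lower numbers stand for lower solubility and higher numbers for higher solubility. Compound 1 `NCc1csc(NC(=O)c2ccon2)n1` gives 50 ug/mL, compound 2 `CC(=O)NCc1csc(NC(=O)c2cc(C(C)(C)C)nn2Cc2ccccc2)n1` gives 12.5 ug/mL, and compound 3 `CC(C)(C)c1cc(C(=O)Nc2ccccn2)n(Cc2ccccc2)n1` gives 6.3 ug/mL. Compound 3 therefore stands within the scatter of compound 2, while compound 1 reads higher than compound 3, beyond the scatter.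

The next compound to be measured is compound 4 `CC(C)(C)c1cc(C(=O)Nc2cccnc2)n(Cc2ccccc2)n1`. It has the same atoms as compound 3, joined differently: pyridin-3-yl in place of pyridin-2-yl on an amide-type nitrogen. In words, pyridin-3-yl takes the place of pyridin-2-yl on an amide-type nitrogen, and the rest of the structure stays the same.

For the measured compounds named here, no two measured compounds differ in only one place, so the data offer no measured step to serve as a guide for this change. The expectation in this assay is anchored only on compound 3 at 6.3 ug/mL, and the uncertainty around it is correspondingly wide. A small upward move is expected, with a 1.6-fold higher number from compound 3 to compound 4 (0.20 log units; within the scatter) estimated to stay within the scatter. For compound 4 the estimated value is 10 ug/mL, with an expected range from 4 ug/mL to 30 ug/mL.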

Compound 4, solubility: 6.3 ug/mL
The estimate for compound 4 lay 1.6-fold (0.20 log units) above the measured number; the range from low to high includes it.
By their numbers in this assay, from the lowest: compounds 3, 4 and 2 (each within the scatter of the next); then compound 1.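

In this assay, for the compounds shown here, the exchange of pyridin-2-yl for pyridin-3-yl on an amide-type nitrogen gives no change at the digits printed from compound 3 to compound 4 (within the scatter) and supplies the first measured step in which only one place differs. Until now, the compounds shown could not isolate any single change, whereas this pair shows that, at this place and on this core, two groups with the same heavy atoms and the same counts of hydrogen-bond donors and acceptors read alike in this assay. No measurement at hand offers an explanation for this outcome.

A single step at a single place leaves open whether pyridin-4-yl, phenyl, or a pyridine ring carrying an amine or a carboxylic acid on the same amide-type nitrogen would also leave the read-out unmoved. It also leaves open whether the exchange of pyridin-2-yl for pyridin-3-yl would read the same way on a different core, or alongside a replacement of the benzyl or tert-butyl group that compound 3 and compound 4 share.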